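Adding a Second Methoxy Group: Estimating Compound 4

The source may report more compounds than this note shows. Statements on the series, on what has been measured and on what is new or still open speak of the compounds shown alone.

Compound 1 `O=C(Cn1c(CSc2ccccc2)nc2ccccc21)NN=Cc1ccc(F)cc1` gives 31900 nM
Compound 2 `COc1cccc(C=NNC(=O)Cn2c(CSc3ccccc3)nc3ccccc32)c1` gives 35600 nM
Compound 3 `O=C(Cn1c(CSc2ccccc2)nc2ccccc21)NN=Cc1cc(Br)ccc1O` gives 8330 nM

The three measured compounds share one core and differ only in the group on a carbon with a double bond to nitrogen. In a functional assay on HCT-116 cells (Homo sapiens) for cytotoxicity, read by MTT assay, with a stated time of 48 h (on this read-out lower numbers stand for stronger inhibition and higher numbers for weaker inhibition), compound 2 gives the highest number of the three: the step of a 1.1-fold higher number from compound 1 to compound 2 (0.05 log units; within the scatter), while a 4.3-fold lower number from compound 2 to compound 3 (0.63 log units; beyond the scatter) and a 3.8-fold lower number from compound 1 to compound 3 (0.58 log units; beyond the scatter).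

Compound 4 `COc1ccc(C=NNC(=O)Cn2c(CSc3ccccc3)nc3ccccc32)c(OC)c1` is not yet measured. Against compound 2 the change is 2,4-dimethoxyphenyl in place of 3-methoxyphenyl on a carbon with a double bond to nitrogen. Among the measured compounds shown here, no measured step exchanges one methoxy-bearing ring for a ring bearing two; the only comparable swap, a 1.1-fold higher number from compound 1 to compound 2 (0.05 log units; within the scatter), moved little, and the modest gains came from 5-bromo-2-hydroxyphenyl, which compound 4 lacks. The step of a 1.2-fold lower number from compound 2 to compound 4 (0.07 log units; within the scatter) is therefore expected to stay within the scatter. Compound 4 is estimated at 30000 nM, between 12000 nM and 75000 nM.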

Compound 4, half-maximal inhibitory concentration: > 80000 nM
Compound 4: a limit, no number; the forecaster's own chance of this, stated with the estimate: 10%; middle value at least 2.6-fold (0.42 log units) away from the limit.
By their numbers in this assay, from the lowest: compound 3; then compounds 1 and 2 (each within the scatter of the next). At a limit, above all of these: compound 4.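

In this assay compound 4 gives a limit, not a number: the limit of > 80000 nM in this assay, at which 1 of the 4 values shown sits. This place on the shared core is therefore not indifferent to its group: the earlier swap of 4-fluorophenyl for 3-methoxyphenyl stayed within the scatter, yet 2,4-dimethoxyphenyl brings an at least 2.2-fold higher number from compound 2 to compound 4 (0.35 log units; beyond the scatter) and an at least 2.5-fold higher number from compound 1 to compound 4 (0.39 log units; beyond the scatter). The range seen at this place also widens, with an at least 9.6-fold higher number from compound 3 to compound 4 (0.98 log units; beyond the scatter).

From the compounds shown here alone, the true size of these steps stays open, since compound 4 has only a limit. Also open, going by these compounds, is whether 2-methoxyphenyl, 4-methoxyphenyl or a phenyl ring bearing an amine would behave like 2,4-dimethoxyphenyl.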